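Cyano for fluoro on the benzyl arm of compound 1

The compounds below may be only part of what the source reports. "The series", "measured", "known", "first", "only" and "open" are said of these compounds alone.

Compound 1 `O=c1ccoc2cc(OCc3cn(Cc4cccc(F)c4)nn3)ccc12` carries a fluoro group on its benzyl ring. In a functional assay on QGY7701 cells (Homo sapiens) for cytotoxicity, read by MTT assay, with a stated time of 48 h (a lower number here means a stronger inhibitor, a higher number a weaker inhibitor), compound 1 reaches only the limit of the assay, > 100000 nM, and not a number. Its partner compound 2 `O=c1ccoc2cc(OCc3cn(Cc4cccc(Br)c4)nn3)ccc12` gives 17600 nM in this assay. Compound 3 `Cc1ccccc1Cn1cc(COc2ccc3c(=O)ccoc3c2)nn1` also stops at the limit of the assay, > 100000 nM. Of the steps seen, an at least 5.6-fold lower number from compound 1 to compound 2 (0.75 log units; beyond the scatter) and an at least 5.6-fold higher number from compound 2 to compound 3 (0.75 log units; beyond the scatter) are the readable ones, while the step from compound 1 to compound 3 leaves its size unreadable because both sit at the limit of > 100000 nM in this assay, at which 2 of the 3 values shown sit. Compound 4 `N#Cc1cccc(Cn2cc(COc3ccc4c(=O)ccoc4c3)nn2)c1` differs from compound 1 by cyano in place of fluoro on an aromatic carbon. Among the compounds with values here, no measured step exchanges fluoro for cyano, so the expectation rests on compound 1 alone, whose value is a limit, and on the fact that only compound 2 among the three has left that limit. Compound 4 is therefore expected to stay weak, with a step of about an at least 1.2-fold lower number from compound 1 to compound 4 (0.09 log units; that floor lies within the scatter). The estimate for compound 4 in this assay is 80000 nM, within 20000 nM to 200000 nM.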

Compound 4, half-maximal inhibitory concentration: 24400 nM
Beside the measured number, compound 4's estimate is 3.3-fold (0.52 log units) above it; the measured number falls inside the stated range.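

In this assay, cyano on this aromatic carbon of the benzyl arm leaves the limit that fluoro had not left, with an at least 4.0-fold lower number from compound 1 to compound 4 (0.61 log units; beyond the scatter), and the 3-cyanophenyl arm also stands clear of the 2-methylphenyl arm, with an at least 4.0-fold lower number from compound 3 to compound 4 (0.61 log units; beyond the scatter). Bromo is thus no longer the only group shown here to give a readable number, and cyano and bromo cannot be told apart, with a 1.4-fold higher number from compound 2 to compound 4 (0.14 log units; within the scatter). The steps out of compound 1 and compound 3 give only a floor for their size, as both compounds remain at a limit: the limit of > 100000 nM in this assay, at which 2 of the 4 values shown sit.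

The compounds shown leave open how far these steps really reach, since the true values behind the limit are unknown. They also leave open whether an amine or a carboxylic acid in place of cyano would give a readable number in this assay.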